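A few compounds are considered here, and "the series" means these few. Any claim that something is new, unique, unknown or untested is made for them only; others in the source may bear on it.

Measured so far in a functional assay on Ehrlich cells (Mus musculus) for cytotoxicity, read by LDH release, with a stated time of 48 h; on this read-out higher numbers stand for weaker inhibition and lower numbers for stronger inhibition:
- compound 1 `Cc1ccc(C(=O)c2ccc(OCC(=O)Nc3nc(-c4ccccc4)cs3)c(C)c2)cc1` at 30500 nM
- compound 2 `Cc1cc(C(=O)c2ccccc2F)ccc1OCC(=O)Nc1nc(-c2ccccc2)cs1` at 16900 nM

Among the compounds with values here, only two numbers exist, and compound 2 cannot be separated from compound 1 on them: a 1.8-fold lower number from compound 1 to compound 2 (0.26 log units; within the scatter) is the whole gap. Compound 3 `Cc1cc(C(=O)c2ccccc2C)ccc1OCC(=O)Nc1nc(-c2ccccc2)cs1` is still unmeasured. The next step is methyl in place of fluoro on an aromatic carbon with methyl in place of fluoro on an aromatic carbon, ortho to a large group. Within the data shown here, one measured step bears on it, a 1.8-fold lower number from compound 1 to compound 2 (0.26 log units; within the scatter) at the same aryl group on the carbonyl carbon, and it stays within the scatter. The data hold no direct comparison of fluoro and methyl at this carbon. No step beyond the scatter is therefore expected in this assay in either direction. The expected change is a 1.2-fold higher number from compound 2 to compound 3 (0.07 log units; within the scatter) and this is no more than a small drift. Compound 3 is estimated at 20000 nM with an expected range from 8000 nM to 50000 nM for its measurement.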

Compound 3, half-maximal inhibitory concentration: 26400 nM
For compound 3 the middle estimate is 1.3-fold (0.12 log units) below the measured one; the range from low to high includes it.
By their numbers in this assay, from the lowest: compounds 2, 3 and 1 (each within the scatter of the next).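

In this assay, the direct comparison at this aromatic carbon, ortho to a large group, shows methyl in place of fluoro giving a 1.6-fold higher number from compound 2 to compound 3 (0.19 log units; within the scatter) on the 2-substituted aryl group. The second comparison, 2-methylphenyl in place of 4-methylphenyl on the carbonyl carbon, gives a 1.2-fold lower number from compound 1 to compound 3 (0.06 log units; within the scatter) and so separates neither the two placements of the methyl nor the compounds in this assay. Nothing available on these compounds offers an explanation for either step.

On these data alone, whether an amine or a carboxylic acid on this aromatic carbon would give a step beyond the scatter stays open. Also open, as far as these compounds go, is what a change elsewhere in the shared core, such as a longer chain, would do in this assay on this read-out.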